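The source may hold more compounds than are shown below. What is called first, only, known or untested is meant among the compounds shown, and "the series" means these compounds.

Measured so far in a functional assay on the whole organism (strain Sprague-Dawley) for inhibition, with Rattus norvegicus as the target, with a stated time of 10 min; a higher number here means that more compound is needed for the effect, a lower number that less compound is needed:
- compound 1 `CCOC(=O)c1cnc(-c2ccccc2Cl)[nH]c1=O`: 5 mg/kg
- compound 2 `CCCCCOc1ccccc1-c1ncc(C(=O)OCC)c(=O)[nH]1`: 2 mg/kg

Compound 2, at 2 mg/kg, has the lower of these two numbers. Compound 3 `CCOC(=O)c1cnc(-c2ccccc2SCC)[nH]c1=O` has ethylsulfanyl in place of pentyloxy on an aromatic carbon. Among the compounds with values here, only one measured step bears on this change: a 2.5-fold lower number from compound 1 to compound 2 (0.40 log units; beyond the scatter), a modest step at that same carbon. Within the data shown here, no measured compound carries ethylsulfanyl, so this single step is the only guide to size. A similarly modest step toward a higher number is expected, a 1.5-fold higher number from compound 2 to compound 3 (0.18 log units; within the scatter). For compound 3 the estimate is 3 mg/kg, with an expected range of 1 mg/kg to 8 mg/kg.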

Compound 3, dose for 50% inhibition: > 5 mg/kg
Compound 3: a limit, no number; the forecaster's own chance of this, stated with the estimate: 5%; at least 1.6-fold (0.22 log units) between middle value and limit.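

In this assay compound 3 gives > 5 mg/kg, a limit of the assay and not a number. Until now this aromatic carbon had only shown a lower number, with pentyloxy in place of chloro; ethylsulfanyl in place of pentyloxy goes the other way, with an at least 2.5-fold higher number from compound 2 to compound 3 (0.39 log units; beyond the scatter). With ethylsulfanyl in place of chloro there is a number no lower from compound 1 to compound 3 (the limit leaves the size open), and the size of this step cannot be read.

Ethylsulfanyl differs from pentyloxy both in its sulfur and in its shorter chain, and the compounds shown do not separate the two. Going by these compounds, whether an ethoxy or a pentylsulfanyl group would behave like pentyloxy remains open.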